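This account rests on a few compounds, and the source may have more. Where it says the series, first, only, none or still open, it means among the compounds named here.

Measured so far:
compound 1, `CCOCCNC(=O)n1cc(-c2ccccc2)oc1=O`, 2040 nM
compound 2, `COc1ccc(-c2cn(C(=O)NCCCCc3ccccc3)c(=O)o2)cc1`, 400 nM

Both numbers come from an assay on isolated protein for inhibition of acid ceramidase (Homo sapiens), read by LC-MS, with a stated time of 1 h; on this read-out higher numbers stand for weaker inhibition and lower numbers for stronger inhibition. Compound 2 gives the lower of the two values, and the gap to compound 1 lies beyond the scatter. For the measured compounds named here, compound 1 and compound 2 differ in more than one place, so their two values show only that the pair sits apart; no single change can be read off from them.

Compound 3, `O=C(NCCCCc1ccccc1)n1cc(-c2ccncc2)oc1=O`, is not yet measured in this assay. It keeps the chain ending in a phenyl group from compound 2 and alters only the aromatic group on the core: pyridin-4-yl in place of 4-methoxyphenyl on an aromatic carbon. Going by the values given here, no step between two measured compounds that differ in one place is available, so the weight of this change has no precedent. The expected step is a 2.0-fold higher number from compound 2 to compound 3 (0.30 log units; within the scatter), a modest move toward a higher number, estimated as near the edge of the scatter rather than a large loss. Compound 3 is expected to give 800 nM, with a range from 250 nM to 2500 nM.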

Compound 3, half-maximal inhibitory concentration: 18 nM
The estimate for compound 3 lay 44-fold (1.65 log units) above the measured number; measured number outside the range, below it.
By their numbers in this assay, from the lowest: compound 3; then compound 2; then compound 1.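

In this assay, for the compounds shown here, the aromatic group on the aromatic carbon next to the ring oxygen carries far more weight than the earlier compounds could show: with the chain ending in a phenyl group held constant, pyridin-4-yl in place of 4-methoxyphenyl gives a 22-fold lower number from compound 2 to compound 3 (1.35 log units; beyond the scatter) and this step lies beyond the scatter. Going by these compounds alone, compound 1 and compound 2 differ in more than one place, so this is the first change that can be read on its own, and it shows that this position alone can move the number by a large step. Nothing at hand accounts for the size of the step, and no measurement of any property of these groups bears on it.

Within the data shown here, the single step swaps a ring of carbon only for one with a hetero atom and also removes the methoxy group, so it cannot say which of these matters; an unsubstituted phenyl or a pyridin-3-yl group on the same chain would help separate them. Also open, going by these compounds, is whether pyridin-4-yl gives a similar step with the chain of compound 1 or with a longer chain, or whether an aminopyridine at this position keeps the low number.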